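The source may hold more compounds than are shown below. What is called first, only, known or untested is meant among the compounds shown, and "the series" means these compounds.

Working notes on the series. Going by the values given here, compound 2 `Cc1ccc(S(=O)(=O)NCc2cn(C[C@H](O)[C@H]3OC(=O)C(OCc4ccccc4)=C3OCc3ccccc3)nn2)cc1` gives the highest of the two numbers so far in a functional assay on SW-620 cells (Homo sapiens) for antiproliferative activity, read by MTT assay, with a stated time of 72 h (a lower number here means a stronger inhibitor, a higher number a weaker inhibitor), at 45800 nM, but its nearest neighbour compound 1 `O=C1O[C@H]([C@@H](O)Cn2cc(CNS(=O)(=O)c3ccc(F)cc3)nn2)C(OCc2ccccc2)=C1OCc1ccccc1`, which in this assay gives 41100 nM, sits within the scatter of it, so no order between the two can be read. Among the compounds with values here, the one step measured, a 1.1-fold higher number from compound 1 to compound 2 (0.05 log units; within the scatter), exchanges methyl for fluoro on an aromatic carbon and stays within the scatter.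

Compound 3 `O=C1O[C@H]([C@@H](O)Cn2cc(CNS(=O)(=O)c3ccc(Cl)cc3F)nn2)C(OCc2ccccc2)=C1OCc1ccccc1` is not yet measured in this assay. It differs from compound 2 in one place: 4-chloro-2-fluorophenyl in place of 4-methylphenyl on a sulfonyl sulfur. Within the data shown here, the only step that bears on it is the one from compound 1 to compound 2, which is itself within the scatter and varies the same aromatic ring on the sulfonyl sulfur; no step with a chloro or a second halogen on that ring is available. The expectation is therefore a step of a 1.1-fold lower number from compound 2 to compound 3 (0.04 log units; within the scatter), with no direction beyond the scatter claimed. For compound 3 the estimated value in this assay is 42000 nM, with a range from 15000 nM to 110000 nM.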

Compound 3, half-maximal inhibitory concentration: 42400 nM
Beside the measured number, compound 3's estimate is 1.0-fold (0.00 log units) below it; low and high end bracket the measured number.
By their numbers in this assay, from the lowest: compounds 1, 3 and 2 (each within the scatter of the next).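

In this assay, 4-chloro-2-fluorophenyl in place of 4-methylphenyl on a sulfonyl sulfur gives a 1.1-fold lower number from compound 2 to compound 3 (0.03 log units; within the scatter), and the same group in place of 4-fluorophenyl gives a 1.0-fold higher number from compound 1 to compound 3 (0.01 log units; within the scatter). Going by these compounds alone, the single earlier step covered only a methyl and a fluoro on this ring; the series now shows that a ring bearing both a chloro and a fluoro also stays within the scatter of the other two compounds, so these three aryl groups on the sulfonyl sulfur cannot be told apart in this read-out. No further measurement bears on why the three numbers cannot be separated.

Going by these compounds, all three compounds carry a halogen- or methyl-substituted phenyl on the sulfonyl sulfur, so it remains open whether an amine, a carboxylic acid or a longer alkyl chain on that ring, or a saturated ring in place of the phenyl, would give a step beyond the scatter. On these data alone, it also remains open whether a free hydroxyl in place of the benzyl ethers on the shared core would change the number, and whether the sulfonyl substituent would then matter.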